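Notes on the amine substituent of the shared core

The source may hold more compounds than are shown below. What is called first, only, known or untested is meant among the compounds shown, and "the series" means these compounds.

Measured compounds:
compound 1, `NS(=O)(=O)OC[C@@H]1C[C@@H](n2nnc3c(NCc4ccco4)ncnc32)C[C@@H]1O`, in an assay on a protein complex for inhibition of NEDD8 activating enzyme (Homo sapiens), read by HTRF, with a stated time of 2 h, in the presence of a further agent that is not named here; on this read-out higher numbers stand for weaker inhibition and lower numbers for stronger inhibition: 30.6 nM
compound 2, `CCCCCCNc1ncnc2c1nnn2[C@@H]1C[C@@H](COS(N)(=O)=O)[C@@H](O)C1`, in this assay: 21.1 nM

Going by the values given here, compound 2 gives 21.1 nM in this assay, and the only other number, that of compound 1, lies within the scatter of it; the step of a 1.5-fold lower number from compound 1 to compound 2 (0.16 log units; within the scatter) is the single measured comparison so far.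

Compound 3, `NS(=O)(=O)OC[C@@H]1C[C@@H](n2nnc3c(NC4CCCC4)ncnc32)C[C@@H]1O`, differs from compound 2 by cyclopentyl in place of hexyl on a nitrogen on an aromatic ring. No measured step exchanges a chain for a ring on this nitrogen, so the expectation rests only loosely on the one step shown, a 1.5-fold lower number from compound 1 to compound 2 (0.16 log units; within the scatter), in which a change of the group on the amine moved the number within the scatter. On that basis compound 3 is estimated to stay close to compound 2, with a step of a 1.0-fold higher number from compound 2 to compound 3 (0.02 log units; within the scatter) and no direction claimed beyond the scatter. The estimate for compound 3 in this assay is 22 nM, with a range from 8 nM to 60 nM.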

Compound 3, half-maximal inhibitory concentration: > 10000 nM
Compound 3 was reported as a limit; the forecaster's own chance of this, stated with the estimate: 3%; middle value at least 450-fold (2.65 log units) from the limit.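

Going by these compounds alone, this nitrogen on an aromatic ring proves far less forgiving than the earlier pair suggested: in this assay, hexylamino to cyclopentylamino gives an at least 470-fold higher number from compound 2 to compound 3 (2.67 log units; beyond the scatter), and replacing (furan-2-yl)methyl with cyclopentyl gives an at least 320-fold higher number from compound 1 to compound 3 (2.51 log units; beyond the scatter), whereas the only earlier step lay within the scatter. The reading for compound 3 is a limit of the assay, not a number: the limit of > 10000 nM in this assay, at which 1 of the 3 values shown sits. Of the three groups, only cyclopentyl has a ring carbon bound directly to this nitrogen, and only compound 3 shows the large loss, though three compounds make this an observation rather than a pattern.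

Going by these compounds, it remains open whether the ring itself or the branching at the carbon on the nitrogen matters, which a cyclopentylmethyl or isopropyl group could separate. The response to ring size, as with cyclohexyl, is also unknown.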